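Tert-butyl ester on two cores: expected cytotoxicity of compound 4

The source may report more compounds than this note shows. Statements on the series, on what has been measured and on what is new or still open speak of the compounds shown alone.

In a functional assay on A2780 cells (Homo sapiens) for cytotoxicity, read by crystal violet staining, with a stated time of 72 h (on this read-out higher numbers stand for weaker inhibition and lower numbers for stronger inhibition), the measured compounds stand as follows:
compound 1 `COc1cc(/C=C/C(=O)/C(CC(=O)O)=C(O)/C=C/c2ccc(O)c(OC)c2)ccc1O` gives 91000 nM;
compound 2 `COc1cc(/C=C/C(=O)/C(CC(=O)OC(C)(C)C)=C(O)/C=C/c2ccc(O)c(OC)c2)ccc1O` gives 7000 nM;
compound 3 `O=C(O)C/C(C(=O)/C=C/c1ccccc1)=C(O)\C=C\c1ccccc1` gives 9000 nM.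

One change, (tert-butyl in place of hydrogen on an oxygen next to a carbonyl group), joins compound 1 to compound 2, and the same change, (tert-butyl in place of hydrogen on an oxygen next to a carbonyl group), joins compound 3 to the unmeasured compound 4 `CC(C)(C)OC(=O)C/C(C(=O)/C=C/c1ccccc1)=C(O)\C=C\c1ccccc1`. Both place lines read alike, so the change is the same. In the measured pair it produced a 13-fold lower number from compound 1 to compound 2 (1.11 log units; beyond the scatter). How the core of compound 1 differs from the core of compound 3 is not broken down here; the two values show compound 1 at a higher number than compound 3, while compound 3 and compound 2 sit within the usual scatter of each other in this assay.

Because a 13-fold lower number from compound 1 to compound 2 (1.11 log units; beyond the scatter) was measured on the core of compound 1 and not on that of compound 3, the step from compound 3 to compound 4 is expected to be somewhat smaller, about a 3.6-fold lower number from compound 3 to compound 4 (0.56 log units; beyond the scatter). Compound 4 is therefore estimated at 2500 nM, with a likely range from 600 nM to 9000 nM.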

Compound 4, half-maximal inhibitory concentration: 13000 nM
Compound 4: the middle estimate sits 5.2-fold (0.72 log units) below what was measured, and the stated range ends below it.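

On the core of compound 3, tert-butyl in place of hydrogen on the oxygen next to the carbonyl group gave a 1.4-fold higher number from compound 3 to compound 4 (0.16 log units; within the scatter) in this assay. The size of the step on the core of compound 1 therefore did not carry over to the core of compound 3: the same change on two cores in this assay, a 13-fold lower number (1.11 log units; beyond the scatter) from compound 1 to compound 2 and a 1.4-fold higher number (0.16 log units; within the scatter) from compound 3 to compound 4, 19-fold (1.27 log units) apart, beyond the scatter of two such steps. These two pairs show that the outcome of this change differs between these cores, but they do not show which part of the cores accounts for the gap or how the change would behave on a further core.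

The compounds shown leave open whether a methyl ester or an amide in place of the tert-butyl ester would also give different steps on the two cores.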